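Cytotoxicity notes on the nitro-trifluoromethyl thiochromenone series

The compounds below may be only part of what the source reports. "The series", "measured", "known", "first", "only" and "open" are said of these compounds alone.

The series shares one core, seen in compound 1 `O=c1cc(NCc2ccccc2)sc2c([N+](=O)[O-])cc(C(F)(F)F)cc12`. In an ADME assay on Vero cells (Chlorocebus sabaeus) for cytotoxicity, read by MTT assay, with a stated time of 48 h (on this read-out higher numbers stand for weaker inhibition and lower numbers for stronger inhibition), compound 1 reaches only a limit, > 64 ug/mL. Compound 2 `COc1ccc(CNc2cc(=O)c3cc(C(F)(F)F)cc([N+](=O)[O-])c3s2)cc1OC` carries 3,4-dimethoxyphenyl in place of phenyl on the saturated chain carbon bound to the ring nitrogen. In this assay compound 2 likewise returns a limit, > 64 ug/mL. Compound 3 `O=c1cc(NCC2CCCCC2)sc2c([N+](=O)[O-])cc(C(F)(F)F)cc12` carries cyclohexyl at the same place. In this assay compound 3 again gives a limit, > 64 ug/mL. Compound 3 therefore stands where every measured member stands, at the limit of > 64 ug/mL in this assay, at which 3 of the 3 values shown sit, and none of the three is separated from the others.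

The measured steps cannot be sized: from compound 1 to compound 2 a step that the two limits leave unreadable from compound 1 to compound 2, from compound 1 to compound 3 a step that the two limits leave unreadable from compound 1 to compound 3, and from compound 2 to compound 3 a step that the two limits leave unreadable from compound 2 to compound 3. Aromatic, dimethoxy-substituted aromatic and saturated rings at this position all sit at the same limit.

Compound 4 `O=c1cc(NCc2ccc(F)cc2)sc2c([N+](=O)[O-])cc(C(F)(F)F)cc12` is not yet measured. It differs from compound 3 as follows (4-fluorophenyl in place of cyclohexyl on a saturated chain carbon bound to a nitrogen on an aromatic ring).

Because every measured value sits at the limit of > 64 ug/mL in this assay, at which 3 of the 3 values shown sit, no step beyond the scatter is expected for this assay from compound 3 to compound 4, a step that the limit leaves unreadable from compound 3 to compound 4. Compound 4 is estimated in this assay at 80 ug/mL, with a range from 40 ug/mL to 160 ug/mL, and most likely it too reports only a limit.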

Compound 4, half-maximal inhibitory concentration: > 64 ug/mL
Compound 4: only a limit was reported; the forecaster's own chance of this, stated with the estimate: 85%; the middle value lies beyond the limit too.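

Compound 4 adds no readable step: in this assay its steps from compound 1, compound 2 and compound 3 all join one limit to another and cannot be read, and the series stays in one place: the limit of > 64 ug/mL in this assay, at which 4 of the 4 values shown sit.

The compounds shown leave open whether phenyl, 4-fluorophenyl, 3,4-dimethoxyphenyl and cyclohexyl differ at all in this assay.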